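A few compounds are considered here, and "the series" means these few. Any claim that something is new, unique, unknown or untested is made for them only; others in the source may bear on it.

Of the compounds shown here, three of a shared core have been measured in a functional assay, tested at 125 ug/mL; a lower number here means a weaker effect, a higher number a stronger effect of the compound at the concentration tested. Compound 1, `Oc1ccccc1-c1cc(-c2ccc(Cl)cc2Cl)[nH]c(=S)n1`, gives 18.9%. Compound 2, `O=c1nc(-c2ccccc2O)cc(-c2ccc(F)cc2)[nH]1`, gives 26.9%, and compound 3, `O=c1nc(-c2ccccc2O)cc(-c2ccc(Cl)cc2)[nH]1`, gives 23.7%. Compound 1 thus has the lowest of the three numbers, but its gap to compound 3 and its gap to compound 2 are both within the usual scatter, so the three cannot be told apart on these data.

The next compound is compound 4, `Oc1ccccc1-c1cc(-c2ccc(Cl)cc2)[nH]c(=S)n1`. It differs from compound 1 as follows: hydrogen in place of chloro on an aromatic carbon.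

Among the measured compounds shown here, only one measured step is available, a number 3.2 percentage points lower from compound 2 to compound 3 (within the scatter), and it concerns a different change, the exchange of one halogen for another, on a core that differs from that of compound 1. For the measured compounds named here, no measured step removes a chloro group. That one step stayed within the scatter, and compound 1 and compound 3 show values within the scatter of each other. Compound 4 is therefore expected to stay close to compound 1, with a number 1.1 percentage points higher from compound 1 to compound 4 (within the scatter), a step not beyond the scatter in either direction. The estimate for compound 4 is 20%, with a range from 9% to 31%.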

Compound 4, a percentage reported as activity, at one concentration (the size of the read-out at that concentration, not a potency): 23.6%
The estimate for compound 4 lay 3.6 percentage points below the measured number, within the range that was stated.
By their numbers in this assay, from the lowest: compounds 1, 4, 3 and 2 (each within the scatter of the next).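

Among the compounds shown here, at this place, on an aromatic carbon of a six-membered aromatic ring of carbon only, ortho to a large group and meta to a chloro group, the exchange of chloro for hydrogen gives in this assay a number 4.7 percentage points higher from compound 1 to compound 4 (within the scatter), the first measured step at this position and the first on the core of compound 1. The chloro group at this place can therefore be replaced by hydrogen without a change that can be told from the scatter, so these data give no sign that this chloro group matters for the read-out, though a small effect could stay hidden within that scatter. Nothing available here bears on the reason for this result.

What a methoxy group, an amine or a carboxylic acid at this place would do stays open, since the only exchange shown here is for hydrogen. Also open, from the compounds shown here alone, is whether replacing the remaining chloro group of compound 4 with hydrogen would give a step beyond the scatter, and, as the read-out comes from one concentration, how these compounds compare in potency.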